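Thiazolyl amide in place of methoxyphenyl amide

This account rests on a few compounds, and the source may have more. Where it says the series, first, only, none or still open, it means among the compounds named here.

The series is read in a functional assay on CNE cells (Homo sapiens) for cytotoxicity, read by MTT assay, with a stated time of 72 h; a higher number here means a weaker inhibitor, a lower number a stronger inhibitor. Compound 1 `O=C(/C=C/c1ccccc1)NNC(=O)c1ccccc1O` gives 43700 nM. For compound 2 `COCOc1cc(/C=C/C(=O)OCC(=O)Nc2ccc(OC)cc2)ccc1OCc1ccccc1` only a limit is reported, > 200000 nM. Compound 3 `COc1ccc(NC(=O)COC(=O)/C=C/c2ccc(OCc3ccccc3)c(O)c2)cc1` likewise sits at a limit, > 200000 nM. The step from compound 2 to compound 3, a step that the two limits leave unreadable from compound 2 to compound 3, is hydrogen in place of methoxymethyl on an oxygen on an aromatic ring, and its size cannot be read because both ends sit at the limit of > 200000 nM in this assay, at which 2 of the 3 values shown sit. Compound 4 `COCOc1cc(/C=C/C(=O)OCC(=O)Nc2nccs2)ccc1OCc1ccccc1` differs from compound 2 by 1,3-thiazol-2-yl in place of 4-methoxyphenyl on an amide-type nitrogen. Going by the values given here, no measured step touches this amide-type nitrogen, and compound 2 itself is known only as a limit, so no direction can be read. Compound 4 is expected to stay near that limit, with a number no higher from compound 2 to compound 4 (the limit leaves the size open) as the expected step. The estimate for compound 4 is 200000 nM, between 60000 nM and 300000 nM.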

Compound 4, half-maximal inhibitory concentration: > 200000 nM
Compound 4: only a limit was reported (the forecaster's own chance of this, stated with the estimate: 70%); the middle value sits exactly at the limit.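

No new step can be read between compound 2 and compound 4, as both sit at a limit: the limit of > 200000 nM in this assay, at which 3 of the 4 values shown sit. The compounds shown leave open how 1,3-thiazol-2-yl and 4-methoxyphenyl on the amide-type nitrogen compare in this assay.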